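Methylsulfonyl to Azido: One Swap, No Direct Precedent

This account rests on a few compounds, and the source may have more. Where it says the series, first, only, none or still open, it means among the compounds named here.

compound 1, `CS(=O)(=O)c1ccc(-c2cc(C(=O)O)c3cc(C(=O)c4ccccc4)ccc3n2)cc1`: 77 nM
compound 2, `[N-]=[N+]=Nc1ccc(-c2cc(C(=O)O)c3cccc(C(=O)c4ccccc4)c3n2)cc1`: 57 nM

Both were tested in an assay on isolated protein for inhibition of cytochrome c oxidase subunit 2 (Ovis aries); on this read-out higher numbers stand for weaker inhibition and lower numbers for stronger inhibition. Among the compounds with values here, compound 1 gives one of only two numbers; the other belongs to compound 2, and the two lie within the scatter of each other, so neither stands apart. Compound 3, `[N-]=[N+]=Nc1ccc(-c2cc(C(=O)O)c3cc(C(=O)c4ccccc4)ccc3n2)cc1`, is not yet measured. It differs from compound 1 in one place: azido in place of methylsulfonyl on an aromatic carbon. Within the data shown here, no measured pair shows this exchange on a shared core. Compound 2 carries the same azido group on a different core and gives 57 nM, which offers no hint of a shift beyond the scatter. The expected step of a 1.2-fold lower number from compound 1 to compound 3 (0.07 log units; within the scatter) is therefore small, in no settled direction. Compound 3 is estimated at 65 nM, with a likely range from 25 nM to 180 nM.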

Compound 3, half-maximal inhibitory concentration: 77 nM
Estimate against measurement, compound 3: 1.2-fold (0.07 log units) below; measured number inside the range.
By their numbers in this assay, from the lowest: compounds 2, 1 and 3 (each within the scatter of the next).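

In this assay, azido in place of methylsulfonyl on the shared core gives no change at the digits printed from compound 1 to compound 3 (within the scatter). Within the data shown here, this is the first direct reading of the exchange: at this place, para to a large group, the two groups cannot be told apart, even though azido has fewer heavy atoms and fewer hydrogen-bond acceptors. Nothing available accounts for this result. From the compounds shown here alone, whether an amine or a carboxylic acid at the same place would also read alike remains open, as does whether the same exchange would read alike on the core of compound 2.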